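The compounds below may be only part of what the source reports. "The series", "measured", "known", "first", "only" and "open" are said of these compounds alone.

Measured compounds:
Compound 1 `CC(C)(C)c1ccc(/C=C/C(=O)c2ccc(OCC(=O)N[C@H]3CCOC3=O)cc2)cc1` gives 16400 nM in a functional assay on MCF7 cells (Homo sapiens) for antiproliferative activity, read by MTT assay, with a stated time of 72 h; a lower number here means a stronger inhibitor, a higher number a weaker inhibitor.
Compound 2 `CC(C)c1ccc(NCC(=O)N[C@H]2CCOC2=O)cc1` gives > 64000 nM in this assay, which is a limit of the assay and not a number.
Compound 3 `O=C(CNc1ccc(F)cc1)N[C@H]1CCOC1=O` gives > 64000 nM in this assay, again a limit.

Going by the values given here, compound 1 thus stands as the only measured number among the three; the other two sit at the limit of > 64000 nM in this assay, at which 2 of the 3 values shown sit. Among the compounds with values here, the one step between measured compounds, a step that the two limits leave unreadable from compound 2 to compound 3, runs from one limit to another and cannot be read, so it gives no guidance on how a fluoro group on an aromatic ring shifts potency.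

Compound 4 `O=C(COc1ccc(C(=O)/C=C/c2cccc(F)c2)cc1)N[C@H]1CCOC1=O` differs from compound 1 in one place: 3-fluorophenyl in place of 4-(tert-butyl)phenyl on a double-bonded chain carbon bound to a double-bonded chain carbon. Within the data shown here, no measured step bears on this exchange, so the expectation rests on compound 1 alone and on the usual scatter. Compound 4 is expected to give 22000 nM, in the range 7000 nM to 64000 nM. The expected step is a 1.3-fold higher number from compound 1 to compound 4 (0.13 log units; within the scatter), which is estimated to lie within the scatter rather than beyond it.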

Compound 4, half-maximal inhibitory concentration: > 64000 nM
Compound 4: only a limit was reported; the forecaster's own chance of this, stated with the estimate: 20%; middle value at least 2.9-fold (0.46 log units) away from the limit.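

Exchanging 4-(tert-butyl)phenyl for 3-fluorophenyl on a double-bonded chain carbon bound to a double-bonded chain carbon gives, in this assay, an at least 3.9-fold higher number from compound 1 to compound 4 (0.59 log units; beyond the scatter). Compound 4 gives > 64000 nM, which is a limit of the assay and not a number. This is the first readable step in the series, and it shows that the group at this place matters, since the one measured number does not persist through this single exchange: the limit of > 64000 nM in this assay, at which 3 of the 4 values shown sit.

The exchange removes the tert-butyl group and brings in a fluorine in one move, so the compounds shown cannot tell which of the two accounts for the step. As far as these compounds go, how a plain phenyl or a 4-methoxyphenyl group would read at this same place also remains open.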